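From 3-chlorophenyl to 4-fluorophenyl at the assay limit

The source may report more compounds than this note shows. Statements on the series, on what has been measured and on what is new or still open speak of the compounds shown alone.

Compound 1 `COc1cc(-n2ncnc2-c2ccc(Cl)cc2)cc(OC)c1OC` gives > 10000 nM (a limit)
Compound 2 `COc1cc(-n2ncnc2-c2ccccc2)cc(OC)c1OC` gives > 10000 nM (a limit)
Compound 3 `COc1cc(-n2ncnc2-c2cccc(Cl)c2)cc(OC)c1OC` gives > 10000 nM (a limit)

In a functional assay on MCF7 cells (Homo sapiens) for antiproliferative activity, read by MTT assay, with a stated time of 72 h (on this read-out higher numbers stand for weaker inhibition and lower numbers for stronger inhibition), compound 3 gives > 10000 nM (a limit, not a number). It shares that position with compound 1 and compound 2, so the whole set rests on the limit of > 10000 nM in this assay, at which 3 of the 3 values shown sit (no number among them). Compound 4 `COc1cc(-n2ncnc2-c2ccc(F)cc2)cc(OC)c1OC` has not yet been measured. Its difference from compound 3 is 4-fluorophenyl in place of 3-chlorophenyl on an aromatic carbon (4-fluorophenyl in place of 3-chlorophenyl on an aromatic carbon of a five-membered aromatic ring with 3 nitrogen).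

The measured steps that bear on this change are a step that the two limits leave unreadable from compound 1 to compound 2 (hydrogen in place of chloro) and a step that the two limits leave unreadable from compound 1 to compound 3 (3-chlorophenyl in place of 4-chlorophenyl) and a step that the two limits leave unreadable from compound 2 to compound 3 (chloro in place of hydrogen). Among the compounds with values here, none of them has a readable size, and no fluoro compound has been measured. The expectation therefore leans on compound 1, the 4-chlorophenyl member, with > 10000 nM (a limit). No step beyond the scatter is expected in this assay in either direction, and the assay will most likely report only a limit again. The expected step is a step that the limit leaves unreadable from compound 3 to compound 4 (an estimate set against a limit). For compound 4 the estimated value is 12000 nM (expected range 4000 nM to 40000 nM).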

Compound 4, half-maximal inhibitory concentration: > 10000 nM
Compound 4 gave a limit, no number; the forecaster's own chance of this, stated with the estimate: 85%; the middle value is on the limit's open side.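

In this assay compound 4 gives > 10000 nM, a limit and not a number. No step linking compound 4 to compound 1, compound 2 or compound 3 can be read, because all four share one position: the limit of > 10000 nM in this assay, at which 4 of the 4 values shown sit.

The compounds shown leave open whether any group in this place on the shared core would give a measurable value.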